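Cytotoxicity notes: trimming the oxadiazole substituent in compound 1

The compounds below may be only part of what the source reports. "The series", "measured", "known", "first", "only" and "open" are said of these compounds alone.

Compound 1, `CC(=O)OC[C@H]1O[C@H](OC[C@H](Cn2cc(COc3ccc(-c4noc(NC5CCCCC5)n4)cc3)nn2)OC(C)=O)C=C[C@@H]1OC(C)=O`, has been tested in an ADME assay on HepG2 cells (Homo sapiens) for cytotoxicity, read by MTT assay, with a stated time of 48 h (on this read-out lower numbers stand for higher toxicity in this test and higher numbers for lower toxicity in this test), where compound 1 gives 99.5 ug/mL. This is the highest of the two numbers recorded so far. Among the measured compounds shown here, the only other measured member, compound 2, `CC(=O)OC[C@H]1O[C@H](OC[C@@H](Cn2cc(CN(c3nc(-c4ccc(F)cc4)no3)C3CCCCC3)nn2)OC(C)=O)C=C[C@@H]1OC(C)=O`, gives in this assay a value of 28.8 ug/mL, a lower number than compound 1 by a margin beyond the scatter; the two differ in more than one place, so their gap is noted only as the two values show it.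

Compound 3, `CC(=O)OC[C@H]1O[C@H](OC[C@H](Cn2cc(COc3ccc(-c4noc(C)n4)cc3)nn2)OC(C)=O)C=C[C@@H]1OC(C)=O`, has not yet been measured in this assay. It keeps the shared core of compound 1 and differs from it in one place: methyl in place of cyclohexylamino on an aromatic carbon. In the words of the difference, 5-(cyclohexylamino)-1,2,4-oxadiazol-3-yl becomes 5-methyl-1,2,4-oxadiazol-3-yl.

For the measured compounds named here, no measured pair carries exactly this change, so there is nothing to anchor a direction. The step from compound 1 to compound 3 is expected to stay within the scatter, a 1.1-fold higher number from compound 1 to compound 3 (0.04 log units; within the scatter), with no strong lean either way. Compound 3 is accordingly estimated at 110 ug/mL in this assay, within a range from 55 ug/mL to 220 ug/mL.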

Compound 3, half-maximal cytotoxic concentration: 37.7 ug/mL
Beside the measured number, compound 3's estimate is 2.9-fold (0.47 log units) above it; the whole stated range lies above it.
By their numbers in this assay, from the lowest: compounds 2 and 3 (each within the scatter of the next); then compound 1.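

In this assay, methyl in place of cyclohexylamino on the aromatic carbon next to the ring nitrogen and the ring oxygen gives a 2.6-fold lower number from compound 1 to compound 3 (0.42 log units; beyond the scatter) and thus shows that the number at this position responds to the group it carries. Among the compounds shown here, this is the first one-place step, which the gap between compound 1 and compound 2 could not provide, as those two differ in more than one place. On this read-out the direction means higher toxicity in this test for the methyl compound, with the change removing the six-membered carbon ring and 1 hydrogen-bond donor along with 1 hydrogen-bond acceptor. Nothing at hand bears on the reason for this step.

The compounds shown do not separate the contribution of the carbon ring from that of the linking nitrogen, a question that a plain amino group or a cyclohexyl group on the same carbon would address. From the compounds shown here alone, it also remains open whether the same change gives a step of similar size and direction on other members, as it has been read only once, on the core of compound 1.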